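The compounds below may be only part of what the source reports. "The series", "measured", "known", "first", "only" and "open" are said of these compounds alone.

Measured so far in an ADME assay on cells (Hepatocyte, Homo sapiens) for pharmacokinetics; on this read-out lower numbers stand for slow clearance and higher numbers for fast clearance:
compound 1, `Cc1ccc(CNS(=O)(=O)N2CCN(/C(C=N)=C(\OCC3(C)CC3)C(=O)Nc3cccc(Cl)c3)CC2)cc1N`: 19.6 uL/min
compound 2, `CC1(CO/C(C(=O)Nc2cccc(Cl)c2)=C(/C=N)N2CCN(S(=O)(=O)NCc3ccnc(N)c3)CC2)CC1`: "not determined" (no result reported)

Compound 2 stands nowhere on the numbers: in this assay compound 2 is reported as "not determined" (no result reported), so it cannot be placed against compound 1. Compound 3, `Cc1cc(CNS(=O)(=O)N2CCN(/C(C=N)=C(\OCC3(C)CC3)C(=O)Nc3cccc(Cl)c3)CC2)ccc1N`, derives from compound 2 by 4-amino-3-methylphenyl in place of 2-aminopyridin-4-yl on a saturated chain carbon bound to a sulfonamide nitrogen. With no number for compound 2, the size and direction of this step in this assay cannot be set, and no change beyond the scatter is assumed. Compound 3 carries a group closely related to that of compound 1, and its clearance in this assay is therefore expected near 20 uL/min, in the range 8 uL/min to 45 uL/min, because compound 1 gives 19.6 uL/min.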

Compound 3, intrinsic clearance in a liver preparation (reported as CLH), per the amount of preparation that the assay uses: 13.4 uL/min
For compound 3 the middle estimate is 1.5-fold (0.17 log units) above the measured one; measured number inside the range.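

In this assay, 4-amino-3-methylphenyl in place of 3-amino-4-methylphenyl on a saturated chain carbon bound to a sulfonamide nitrogen gives a 1.5-fold lower number from compound 1 to compound 3 (0.17 log units; within the scatter). Exchanging these two groups at this position therefore leaves the read-out within the scatter, the first comparison available in the series. Steps involving compound 2 cannot be read. No measurement at hand bears on this result. Still open, from the compounds shown here alone, is how this assay responds when a carboxylic acid or a longer chain replaces 4-amino-3-methylphenyl at this position, and where 2-aminopyridin-4-yl stands against either group.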